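A few compounds are considered here, and "the series" means these few. Any claim that something is new, unique, unknown or untested is made for them only; others in the source may bear on it.

Compound 1 `O=C(NO)c1ccc(/C=C/c2ccnc(-c3cc(F)ccc3O)c2)cc1` is one of three stilbene hydroxamic acids examined in a functional assay on MGC-803 cells (Homo sapiens) for antiproliferative activity, read by CellTiter-Glo, with a stated time of 72 h; a higher number here means a weaker inhibitor, a lower number a stronger inhibitor. Compound 1 gives 1920 nM. Compound 3 `Cc1ccc(-c2cc(/C=C/c3ccc(C(=O)NO)cc3)c(F)cn2)c(F)c1` gives 2510 nM, which sits within the usual scatter of compound 1. Compound 2 `COc1ccccc1-c1cc(/C=C/c2ccc(C(=O)NO)cc2)ccn1` gives 6350 nM, and the step from compound 1 to compound 2 is a 3.3-fold higher number from compound 1 to compound 2 (0.52 log units; beyond the scatter), a change of 2-methoxyphenyl in place of 5-fluoro-2-hydroxyphenyl. Compound 1 therefore stands at the low end of the three, set apart clearly only from compound 2.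

Compound 4 `O=C(NO)c1ccc(/C=C/c2ccncc2)cc1` differs from compound 1 by hydrogen in place of 5-fluoro-2-hydroxyphenyl on an aromatic carbon. Among the compounds with values here, the only step bearing on it is the one from compound 1 to compound 2, where changing the substituents on that aromatic ring already gave a modest weakening; removing the ring entirely is a larger change, so a larger weakening is expected in this assay. Compound 4 is estimated at 8000 nM, between 2500 nM and 25000 nM, a step of a 4.2-fold higher number from compound 1 to compound 4 (0.62 log units; beyond the scatter).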

Compound 4, half-maximal inhibitory concentration: 3930 nM
The estimate for compound 4 lay 2.0-fold (0.31 log units) above the measured number; the measured number falls inside the stated range.
By their numbers in this assay, from the lowest: compounds 1, 3, 4 and 2 (each within the scatter of the next, the first and the last beyond it).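

On this aromatic carbon next to the ring nitrogen, the whole 5-fluoro-2-hydroxyphenyl group can be replaced by hydrogen at a modest cost, with a 2.0-fold higher number from compound 1 to compound 4 (0.31 log units; beyond the scatter). The 2-methoxyphenyl group of compound 2 gives no gain over hydrogen that stands clear of the scatter, with a 1.6-fold lower number from compound 2 to compound 4 (0.21 log units; within the scatter), so of these two groups only the 5-fluoro-2-hydroxyphenyl group is set apart from hydrogen. No supporting data are available to explain either step. Open is which part of the 5-fluoro-2-hydroxyphenyl group, the hydroxyl or the fluorine, accounts for that difference. Also open, as far as these compounds go, is how an amine or a methyl group on this carbon would compare.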